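Potassium channel inhibitor series: side-chain swap on the ring nitrogen neighbour

A few compounds are considered here, and "the series" means these few. Any claim that something is new, unique, unknown or untested is made for them only; others in the source may bear on it.

Working notes on a small set of amides sharing one core. Within the data shown here, compound 2 `C[C@H](NC(=O)c1cc(C(F)(F)F)nn1C)c1nc(-c2ccnc(C(F)(F)F)c2)no1` gives 40 nM in an assay on T-REx-293 cells for inhibition of potassium channel subfamily T member 1 (Homo sapiens), read by patch clamp (on this read-out higher numbers stand for weaker inhibition and lower numbers for stronger inhibition), and holds the lowest of the two numbers measured so far; its nearest neighbour is compound 1 `C[C@H](NC(=O)c1cc(C(F)(F)F)nn1C)c1nc(-c2ccnc(C(F)F)c2)no1`, which in this assay gives 61 nM. Among the measured compounds shown here, the only step measured is a 1.5-fold lower number from compound 1 to compound 2 (0.18 log units; within the scatter), so the two compounds cannot be told apart.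

Compound 3 `COC(C)(C)c1cc(-c2noc([C@H](C)NC(=O)c3cc(C(F)(F)F)nn3C)n2)ccn1` has not yet been measured. It differs from compound 2 by 1-methoxy-1-methylethyl in place of trifluoromethyl on an aromatic carbon. For the measured compounds named here, no measured step touches this change: the step from compound 1 to compound 2 alters only the fluorine count on the group that now leaves altogether, and it stayed within the scatter. There is therefore no basis from the measured pair for expecting a shift beyond the scatter in either direction, though the entering group is larger and brings one hydrogen-bond acceptor, which widens the uncertainty. Compound 3 is expected to give about 80 nM in this assay, within 25 nM to 250 nM, amounting to an expected 2.0-fold higher number from compound 2 to compound 3 (0.30 log units; within the scatter).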

Compound 3, half-maximal inhibitory concentration in the potassium channel subfamily T member 1 assay: 6280 nM
Beside the measured number, compound 3's estimate is 79-fold (1.89 log units) below it; measured number outside the range, above it.
By their numbers in the potassium channel subfamily T member 1 assay, from the lowest: compounds 2 and 1 (each within the scatter of the next); then compound 3.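

In the potassium channel subfamily T member 1 assay compound 3 gives 6280 nM and the replacement of trifluoromethyl by 1-methoxy-1-methylethyl on the aromatic carbon next to the ring nitrogen gives a 160-fold higher number from compound 2 to compound 3 (2.20 log units; beyond the scatter) and the replacement of difluoromethyl by the same group gives a 100-fold higher number from compound 1 to compound 3 (2.01 log units; beyond the scatter) in the same direction, so this position, where the two fluorinated groups could not be told apart, does not accept every group. In a physicochemical assay for lipophilicity (on this read-out lower numbers stand for lower lipophilicity and higher numbers for higher lipophilicity), compound 2 gives 3.6 and compound 3 gives 3.8 and the first of these changes gives a number 0.20 log units higher from compound 2 to compound 3 (within the scatter) and so leaves compound 2 and compound 3 indistinguishable on that read-out, whereas the two differ far beyond the scatter in the potassium channel subfamily T member 1 assay on the same change. No supporting data are at hand to explain the large step at this position.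

The compounds shown leave open whether the step follows the branched carbon skeleton or the ether oxygen of 1-methoxy-1-methylethyl, a question on which a tert-butyl group and a plain methoxy group at the same place would bear directly. As far as these compounds go, it also remains open whether a step of this size would recur with an amine or a cyclopropyl group at this position.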